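A few compounds are considered here, and "the series" means these few. Any claim that something is new, unique, unknown or untested is made for them only; others in the source may bear on it.

Working notes on a small set of antagonists examined in a functional assay on CHO cells for antagonist activity at Gonadotropin-releasing hormone receptor (Homo sapiens), read by a luciferase reporter, with a stated time of 30 min; a lower number here means a stronger inhibitor, a higher number a weaker inhibitor. Compound 1 `CCNC(=O)Nc1ccc(-c2nc3n(Cc4c(F)cccc4F)cc(C(=O)OCC)c(=O)n3c2CN(CC(=O)NCc2cn(CCOCCN=[N+]=[N-])nn2)Cc2ccccc2)cc1` gives 525 nM in this assay, and compound 2 `CCNC(=O)Nc1ccc(-c2nc3n(Cc4c(F)cccc4F)cc(C(=O)OCC)c(=O)n3c2CN(CC(=O)NCc2cn(CCOCCOCCN=[N+]=[N-])nn2)Cc2ccccc2)cc1` gives 468 nM. Compound 2 differs from compound 1 by 2-azidoethoxy in place of azido on a saturated chain carbon, two bonds along the chain from an oxygen on a saturated carbon and the step is a 1.1-fold lower number from compound 1 to compound 2 (0.05 log units; within the scatter). Compound 3 `CCNC(=O)Nc1ccc(-c2nc3n(Cc4c(F)cccc4F)cc(C(=O)NCc4cn(CCOCCN=[N+]=[N-])nn4)c(=O)n3c2CN(C)Cc2ccccc2)cc1` carries a different core from compound 1; the difference between the two cores is not broken down here. In this assay compound 3 returns only a limit, < 10000 nM, which is the limit of < 10000 nM in this assay, at which 1 of the 3 values shown sits. Compound 4 `CCNC(=O)Nc1ccc(-c2nc3n(Cc4c(F)cccc4F)cc(C(=O)NCc4cn(CCOCCOCCN=[N+]=[N-])nn4)c(=O)n3c2CN(C)Cc2ccccc2)cc1` applies to compound 3 the change (2-azidoethoxy in place of azido on a saturated chain carbon, two bonds along the chain from an oxygen on a saturated carbon); this is the same change as from compound 1 to compound 2, at the same place. Because the earlier passage of this change gave a 1.1-fold lower number from compound 1 to compound 2 (0.05 log units; within the scatter), the step from compound 3 to compound 4 is expected to be small as well, estimated at a step that the limit leaves unreadable from compound 3 to compound 4. With compound 3 known only as a limit, compound 4 is expected to fall near that limit, estimated at 4000 nM and likely to lie between 800 nM and 10000 nM.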

Compound 4, half-maximal inhibitory concentration: < 10000 nM
Compound 4 gave a limit, no number; the forecaster's own chance of this, stated with the estimate: 50%; the middle value does not contradict the limit.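

Compound 3 and compound 4 both return only a limit, and no new step can be read between them. The limit now reads: the limit of < 10000 nM in this assay, at which 2 of the 4 values shown sit.

The compounds shown leave open whether 2-azidoethoxy in place of azido has any readable effect on the core of compound 3, and how that core truly compares with the core of compound 1.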